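Lengthening the unsaturated chain on the sulfur of compound 3

The source may hold more compounds than are shown below. What is called first, only, known or untested is meant among the compounds shown, and "the series" means these compounds.

Compound 3 `C=CCCSC[C@H](NC(=O)c1ccc(O)cc1)C(=O)OC` is the starting point of this step. In an assay on RAW264.7 cells for antagonist activity at Toll-like receptor 2 (Mus musculus), read by Griess assay, with a stated time of 24 h (a higher number here means a weaker inhibitor, a lower number a stronger inhibitor), compound 3 gives 54900 nM, which is the second highest of the three numbers recorded so far. Its nearest neighbour is compound 1 `C=CCCCSC[C@H](NC(=O)c1cc(O)cc(O)c1)C(=O)OC`, which in this assay gives 57800 nM; the furthest is compound 2 `C#CCSC[C@H](NC(=O)c1cc(O)cc(O)c1)C(=O)OC`, which in this assay gives 41800 nM. All three values sit within the scatter of one another, so no real separation among them can be claimed.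

Compound 4 `C=CCCCSC[C@H](NC(=O)c1ccc(O)cc1)C(=O)OC` differs from compound 3 by allyl in place of vinyl on a saturated chain carbon, two bonds along the chain from a sulfur. Within the data shown here, the only measured step that touches the chain on the sulfur comes from the pair of compounds 1 and 2, which share a different aromatic part: a 1.4-fold lower number from compound 1 to compound 2 (0.14 log units; within the scatter). There a larger alteration of that chain left the number within the scatter. The change from compound 3 to compound 4 is a smaller alteration of the same kind, so the expectation is that this assay shows no step beyond the scatter in either direction, a 1.0-fold higher number from compound 3 to compound 4 (0.00 log units; within the scatter). Compound 4 is therefore estimated at 55000 nM, with a range from 28000 nM to 110000 nM.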

Compound 4, half-maximal inhibitory concentration: 53000 nM
For compound 4 the middle estimate is 1.0-fold (0.02 log units) above the measured one; low and high end bracket the measured number.
By their numbers in this assay, from the lowest: compounds 2, 4, 3 and 1 (each within the scatter of the next).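

Among these compounds, with the aromatic part held fixed, going from (but-3-en-1-yl)sulfanyl to (pent-4-en-1-yl)sulfanyl in this assay gives a 1.0-fold lower number from compound 3 to compound 4 (0.02 log units; within the scatter) and so provides the first reading of this single extension on the sulfur, with no separation between the two chains. The same (pent-4-en-1-yl)sulfanyl chain now appears with two different aromatic parts: compound 1 gives 57800 nM and compound 4 gives 53000 nM in the same assay, and these printed values lie close together. No independent measurement is available to explain why this extension leaves the number within the scatter.

The compounds shown span only short unsaturated chains on the sulfur, so it remains open whether a much longer chain, or a chain ending in an amine or a carboxylic acid, would move the number beyond the scatter. On these data alone, it also remains open how this assay would respond if a carboxylic acid stood in place of the methyl ester that all four compounds share.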